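A few compounds are considered here, and "the series" means these few. Any claim that something is new, unique, unknown or untested is made for them only; others in the source may bear on it.

Compound 3 `CCCCCC(C)Nc1cc(Oc2c(OC)cc3cc(C#N)ccc3c2OC)nc(Nc2ccc(C#N)cc2)n1` is one of three close relatives built on a shared core, all tested in an ADME assay on MT4 cells (Homo sapiens) for cytotoxicity, read by MTT assay, with a stated time of 5 days; a lower number here means that less compound is tolerated, a higher number that more compound is tolerated. In this assay compound 3 gives only a limit, > 125000 nM. Compound 1 `COc1cc2cc(C#N)ccc2c(OC)c1Oc1cc(NCC(C)C)nc(Nc2ccc(C#N)cc2)n1` likewise gives only a limit, > 125000 nM. Compound 2 `CCC(C)Nc1cc(Oc2c(OC)cc3cc(C#N)ccc3c2OC)nc(Nc2ccc(C#N)cc2)n1` also gives only a limit, > 125000 nM. All three sit at the limit of > 125000 nM in this assay, at which 3 of the 3 values shown sit, so the steps a step that the two limits leave unreadable from compound 1 to compound 2, a step that the two limits leave unreadable from compound 1 to compound 3 and a step that the two limits leave unreadable from compound 2 to compound 3 cannot be sized. Compound 4 `COc1cc2cc(C#N)ccc2c(OC)c1Oc1cc(NC2CCC2)nc(Nc2ccc(C#N)cc2)n1` alters the side chain on the same nitrogen: cyclobutyl in place of 1-methylhexyl on a nitrogen on an aromatic ring. The measured steps show only that several different chains on that nitrogen all stayed at the limit, so the step of a number no higher from compound 3 to compound 4 (the limit leaves the size open) is expected to be none beyond the scatter. Compound 4 is therefore estimated at 125000 nM, between 60000 nM and 300000 nM, and will most likely again be reported only as a limit.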

Compound 4, half-maximal cytotoxic concentration: > 125000 nM
Compound 4 gave a limit, no number; the forecaster's own chance of this, stated with the estimate: 85%; the middle value lies on the limit itself.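

Compound 4 gives only a limit, as do compound 1, compound 2 and compound 3, so no step among these compounds can be read: the limit of > 125000 nM in this assay, at which 4 of the 4 values shown sit. Going by these compounds, whether any side chain on that nitrogen would give a measurable number rather than a limit stays open.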